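The source may hold more compounds than are shown below. What is called first, only, known or untested is meant among the compounds shown, and "the series" means these compounds.

Measured so far in an assay for inhibition of Amine oxidase [flavin-containing] A (Rattus norvegicus); a lower number here means a stronger inhibitor, a higher number a weaker inhibitor:
compound 1, `Cc1cccc(COc2ccc(-c3nn(CCC#N)c(=O)o3)cc2)c1`: 20000 nM
compound 2, `Cc1ccc(COc2ccc(-c3nn(CCC#N)c(=O)o3)cc2)cc1`: 25000 nM
compound 3, `Cc1cccc(COc2ccc(-c3nn(CCC#N)c(=S)o3)cc2)c1`: 14000 nM

Compound 1 and compound 2 differ by 4-methylphenyl in place of 3-methylphenyl on a saturated chain carbon bound to an oxygen on an aromatic ring; that change gave a 1.3-fold higher number from compound 1 to compound 2 (0.10 log units; within the scatter). Compound 3 has the lowest number of the three, but its gaps to compound 1 and to compound 2 are both within the scatter, so no order among them is claimed. The difference between the core of compound 3 and the core of compound 1 is not broken down here.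

Compound 4, `Cc1ccc(COc2ccc(-c3nn(CCC#N)c(=S)o3)cc2)cc1`, is not yet measured. It differs from compound 3 by 4-methylphenyl in place of 3-methylphenyl on a saturated chain carbon bound to an oxygen on an aromatic ring, the same change at the same place as between compound 1 and compound 2. Going by the values given here, for compound 4 the expected step is a 1.3-fold higher number from compound 3 to compound 4 (0.11 log units; within the scatter), because a 1.3-fold higher number from compound 1 to compound 2 (0.10 log units; within the scatter) lay within the scatter and is the only precedent. Compound 4 is estimated at 18000 nM in this assay, between 9000 nM and 36000 nM.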

Compound 4, half-maximal inhibitory concentration: 10000 nM
Beside the measured number, compound 4's estimate is 1.8-fold (0.26 log units) above it; the range from low to high includes it.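

In this assay, 4-methylphenyl in place of 3-methylphenyl gives a 1.4-fold lower number from compound 3 to compound 4 (0.15 log units; within the scatter). Set beside the earlier step, the change reads the same on both cores within the scatter: the same change on two cores in this assay, a 1.3-fold higher number (0.10 log units; within the scatter) from compound 1 to compound 2 and a 1.4-fold lower number (0.15 log units; within the scatter) from compound 3 to compound 4, 1.8-fold (0.24 log units) apart, within the scatter of two such steps The two pairs therefore show no dependence of this change on the core, but neither step shows a real effect of the change, so there is no measurable effect to carry from one core to the other, and two cores say nothing about others in the series.

Still open, on these data alone, is whether an amine or a carboxylic acid in place of the methyl, or a longer chain carrying the nitrile, would give a step beyond the scatter. As far as these compounds go, whether such a step would hold across both cores is equally open.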